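A few compounds are considered here, and "the series" means these few. Any claim that something is new, unique, unknown or untested is made for them only; others in the source may bear on it.

Measured compounds:
compound 1 `N#C/C(=C/c1ccc(Cl)cc1)C(=O)c1ccc[nH]1`: 54000 nM
compound 2 `N#C/C(=C/c1ccc(Cl)c(Cl)c1)C(=O)c1ccc[nH]1`: < 10000 nM (a limit)

Both results come from a functional assay on HT-29 cells (Homo sapiens) for cytotoxicity, read by MTT assay, with a stated time of 72 h; a higher number here means a weaker inhibitor of growth, a lower number a stronger inhibitor of growth. Among the compounds with values here, compound 1 gives 54000 nM, the only exact number in this small set. Compound 2 gives < 10000 nM, which is a limit and not an exact number.

Compound 3 `N#C/C(=C/c1ccc(O)cc1)C(=O)c1ccc[nH]1` has not yet been measured. Its difference from compound 1 is hydroxy in place of chloro on an aromatic carbon, which means hydroxy in place of chloro on an aromatic carbon, para to a large group. Within the data shown here, only one measured step bears on this change, and even that one only loosely: an at least 5.4-fold lower number from compound 1 to compound 2 (0.73 log units; beyond the scatter). That step adds a chloro and does not replace one, so it offers a rough scale of size but no firm direction. Among the measured compounds shown here, no measurement yet shows what happens when hydroxy replaces chloro. Going by an at least 5.4-fold lower number from compound 1 to compound 2 (0.73 log units; beyond the scatter), a step of no greater size is expected in this assay, with neither direction favoured, and it may well stay within the scatter.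

For compound 3 the estimated value is 45000 nM, with an expected range from 12000 nM to 150000 nM. This estimate corresponds to an expected 1.2-fold lower number from compound 1 to compound 3 (0.08 log units; within the scatter) overall.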

Compound 3, concentration for 50% growth inhibition: < 10000 nM
Compound 3: a limit, no number (the forecaster's own chance of this, stated with the estimate: 20%); middle value at least 4.5-fold (0.65 log units) away from the limit.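

Hydroxy in place of chloro on an aromatic carbon, para to a large group, gives an at least 5.4-fold lower number from compound 1 to compound 3 (0.73 log units; beyond the scatter) in this assay, so a chloro is not required at this position for this level of growth inhibition. Compound 2 kept this chloro and added a second one, which left open what would happen if the chloro itself were replaced; compound 3 now shows that the replacement does not raise the number, and that the lower number can be reached with no chloro on the ring at all. Compound 3 gives < 10000 nM, a limit and not a number, so the step sets only a bound on the size of the change: the limit of < 10000 nM in this assay, at which 2 of the 3 values shown sit.

Compound 2 and compound 3 differ in more than one place and both are limits, so the compounds shown do not order them against each other. Going by these compounds, it also remains open whether an amine, a methoxy group or a carboxylic acid at this same position would give a number lower than that of compound 1, or whether the result is particular to hydroxy.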